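The source may report more compounds than this note shows. Statements on the series, on what has been measured and on what is new or still open speak of the compounds shown alone.

Working notes on the series. In a functional assay on HCT-116 cells (Homo sapiens) for antiproliferative activity, read by WST assay, with a stated time of 72 h (on this read-out higher numbers stand for weaker inhibition of growth and lower numbers for stronger inhibition of growth), compound 1 `O=C(NO)c1cnc(N2C[C@@H]3[C@H](C2)[C@H]3NCc2ccccc2)nc1` gives 120 nM and compound 2 `CCCCc1ccc(CN[C@H]2[C@@H]3CN(c4ncc(C(=O)NO)cn4)C[C@@H]32)cc1` gives 410 nM, so compound 2 holds the higher of the two numbers, meaning the weaker growth inhibition. The next structure is compound 3 `O=C(NO)c1cnc(N2C[C@@H]3[C@H](C2)[C@H]3NCc2ccc(-c3ccccc3)cc2)nc1`. The change from compound 2 is phenyl in place of butyl on an aromatic carbon, para to a large group.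

Among the measured compounds shown here, only one measured step bears on this change: a 3.4-fold higher number from compound 1 to compound 2 (0.53 log units; beyond the scatter). That step is modest but beyond the scatter, and it comes from butyl in place of hydrogen on an aromatic carbon. For the measured compounds named here, no measured compound yet carries phenyl at this place, so the step offers only a rough guide to size and none to direction. A small step is therefore expected, most likely within the scatter, with a slight lean towards a lower number. The estimated change is a 1.6-fold lower number from compound 2 to compound 3 (0.20 log units; within the scatter). For compound 3 the expected value is 260 nM, with an estimated range of 90 nM to 750 nM.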

Compound 3, concentration for 50% growth inhibition: 56 nM
For compound 3 the middle estimate is 4.6-fold (0.67 log units) above the measured one; measured number below the stated range.
By their numbers in this assay, from the lowest: compound 3; then compound 1; then compound 2.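

In this assay this place, an aromatic carbon para to a large group, turns out to tolerate a substituent with a gain: phenyl in place of hydrogen gives a 2.1-fold lower number from compound 1 to compound 3 (0.33 log units; beyond the scatter) whereas butyl had moved the number the other way. The identity of the group therefore decides the direction here, and phenyl in place of butyl gives a 7.3-fold lower number from compound 2 to compound 3 (0.86 log units; beyond the scatter) which is the largest step seen so far in the series and leaves compound 3 as the strongest growth inhibitor of the three, so any rule that substitution at this place weakens growth inhibition fails on compound 3, while compound 2 goes against any rule that it strengthens it. Nothing at hand explains why these two carbon-only groups part in this way.

With only butyl and phenyl at this place, the ring and the size of the group cannot be told apart, so cyclohexyl or a longer chain would be needed to separate them. From the compounds shown here alone, whether the gain survives with a heteroatom in the group, as in a pyridine ring, an amine or a carboxylic acid, remains open.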